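Swapping an ethyl for an ester on a propoxy chain

This account rests on a few compounds, and the source may have more. Where it says the series, first, only, none or still open, it means among the compounds named here.

Measured compounds:
- compound 1, `CC#CCOc1c(Cl)cc(N/C=N/OCC)cc1Cl`: 4
- compound 2, `CCO/N=C/Nc1cc(Cl)c(OCOC)c(Cl)c1`: 3.7
- compound 3, `C#CCc1c(Cl)cc(N/C=N/OCCC)cc1Cl`: 4

These three share a core carrying two chlorines and a formamidine oxime ether; they differ only in the group attached at the position across the core. In a physicochemical assay for lipophilicity, measured as octanol-water partition (on this read-out lower numbers stand for lower lipophilicity and higher numbers for higher lipophilicity), compound 3 gives 4, level with compound 1 at the digits shown; its gap to compound 2 is within the scatter, so no order can be read among the three.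

Compound 4, `C#CCc1c(Cl)cc(N/C=N/OCC(=O)OCC)cc1Cl`, has not yet been measured. Compared with compound 3 it carries ethoxycarbonyl in place of ethyl on a saturated chain carbon bound to an oxygen.

For the measured compounds named here, only one measured step exists, a number 0.30 log units lower from compound 1 to compound 2 (within the scatter); it concerns a different group at a different place and is within the scatter, so it gives no direct guide. The change to compound 4 adds two hydrogen-bond acceptors and a carbonyl while removing a plain ethyl, a kind of exchange that in this assay usually lowers the number.

Compound 4 is therefore expected to sit lower than compound 3, by an estimated a number 0.70 log units lower from compound 3 to compound 4 (beyond the scatter), at about 3.3 with a likely range from 2.8 to 3.8.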

Compound 4, partition coefficient: 3.6
Compound 4: middle estimate off by 0.30 log units, on the low side; the measured number falls inside the stated range.
By their numbers in this assay, from the lowest: compounds 4, 2, 1 and 3 (each within the scatter of the next, the first and the last beyond it).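

For the compounds shown here, putting ethoxycarbonyl in place of ethyl on a saturated chain carbon bound to an oxygen gives the first step in this assay that lies beyond the scatter, a number 0.40 log units lower from compound 3 to compound 4 (beyond the scatter), so this end of the molecule can shift the read-out, if only modestly. The step comes with a larger group, five heavy atoms in place of two, and with two hydrogen-bond acceptors where ethyl has none. No measurement here explains why the step has this size.

A single exchange cannot separate the part played by the carbonyl from that of the ester's outer ethyl. A carboxylic acid, an amide or a longer plain carbon chain on the same chain carbon would show how far the read-out follows each of these features.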